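The source may report more compounds than this note shows. Statements on the series, on what has been measured and on what is new or still open speak of the compounds shown alone.

Series notes on the shared core. In an assay on CHO cells for displacement of a labelled ligand from adenosine receptor A3 (Homo sapiens), read by scintillation counting, with a stated time of 120 min, tested at 10 uM (a higher number here means more inhibition at the concentration tested (going by the name of the read-out), a lower number less inhibition), compound 3 `COc1ccc(N2CCN(Cc3csc(N)c3C(=O)c3ccc(Cl)cc3)CC2)cc1` gives 0%; it stands level with compound 1 `Nc1scc(CN2CCN(c3cccc(Cl)c3Cl)CC2)c1C(=O)c1ccc(Cl)cc1`, which gives 0%, and these two are together the lowest of the three numbers, while compound 2 `Nc1scc(CN2CCN(c3ccc(Cl)cc3F)CC2)c1C(=O)c1ccc(Cl)cc1` gives 1%. Compound 4 `Nc1scc(CN2CCN(c3cccc(Cl)c3)CC2)c1C(=O)c1ccc(Cl)cc1` is not yet measured. The change is 3-chlorophenyl in place of 4-methoxyphenyl on an amine nitrogen in a ring. Among the compounds with values here, the steps that bear on it are the other swaps of the aryl group on the same amine nitrogen in a ring: no change at the digits printed from compound 1 to compound 3 (within the scatter), a number 1 percentage points lower from compound 2 to compound 3 (within the scatter) and a number 1 percentage points higher from compound 1 to compound 2 (within the scatter), each within the scatter. The step to compound 4 is therefore expected to be a number 1 percentage points higher from compound 3 to compound 4 (within the scatter), nothing beyond the scatter. Compound 4 is estimated at 1%, with an expected range from -8% to 10%.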

Compound 4, a percentage reported as inhibition, at one concentration (the size of the read-out at that concentration, not a potency): 1%
The estimate for compound 4 equals the measured number at the digits printed; the range from low to high includes it.
By their numbers in this assay, from the lowest: compounds 1, 3, 2 and 4 (each within the scatter of the next).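

In this assay the single chloro of 3-chlorophenyl on the amine nitrogen in a ring adds nothing beyond the scatter: a number 1 percentage points higher from compound 3 to compound 4 (within the scatter) and no change at the digits printed from compound 2 to compound 4 (within the scatter) stand with the earlier swaps of the aryl group. Hydrogen in place of chloro on an aromatic carbon, the first change here confined to one substituent, gives a number 1 percentage points higher from compound 1 to compound 4 (within the scatter) and so sets no role for that chloro. No measurement on hand offers an explanation for these readings.

From the compounds shown here alone, whether a phenyl ring carrying an amine or a carboxylic acid, or a longer chain in place of the aryl group, would move the number beyond the scatter stays open. Going by these compounds, the effect of changes elsewhere on the shared core also stays open.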